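Sulfonate aryl swap, compound 1 to compound 3

This account rests on a few compounds, and the source may have more. Where it says the series, first, only, none or still open, it means among the compounds named here.

Compound 1 `O=C(O)CCCCCCC(=O)Nc1ccc(C2=C(c3ccc(O)cc3)C3CC(S(=O)(=O)Oc4ccc(C(F)(F)F)cc4)C2O3)cc1` in an ADME assay on Vero cells (Chlorocebus sabaeus) for inhibition, read by MTT assay, with a stated time of 72 h (a higher number here means a weaker inhibitor, a lower number a stronger inhibitor), gives only a limit, > 100000 nM. Compound 2 `O=C(O)CCCCCCC(=O)Nc1cccc(OS(=O)(=O)C2CC3OC2C(c2ccc(O)cc2)=C3c2ccc(O)cc2)c1` likewise returns a limit in this assay, > 100000 nM. Both shown values sit at the limit of > 100000 nM in this assay, at which 2 of the 2 values shown sit, so compound 1 stands at the limit together with the one other compound measured. Compound 3 `Cc1ccccc1OS(=O)(=O)C1CC2OC1C(c1ccc(NC(=O)CCCCCCC(=O)O)cc1)=C2c1ccc(O)cc1` differs from compound 1 by 2-methylphenyl in place of 4-(trifluoromethyl)phenyl on an oxygen. Among the measured compounds shown here, no step between measured compounds is available here; with both values at the limit, the expected step of a number no higher from compound 1 to compound 3 (the limit leaves the size open) is none beyond the scatter. Compound 3 is therefore estimated at 100000 nM, within 30000 nM to 300000 nM, most likely reported again as a limit.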

Compound 3, half-maximal inhibitory concentration: > 100000 nM
Compound 3: a limit, no number; the forecaster's own chance of this, stated with the estimate: 75%; the middle value lies on the limit itself.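

Among the compounds shown here, compound 1 and compound 3 both return only limits in this assay so no step between them can be read. The compounds shown leave open whether 2-methylphenyl and 4-(trifluoromethyl)phenyl differ in this assay at any concentration.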